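Replacing the aryl amide with a hydroxamic acid

The source may hold more compounds than are shown below. What is called first, only, known or untested is meant among the compounds shown, and "the series" means these compounds.

Of the compounds shown here, two built on one shared core have been tested in a functional assay on CLL cells (Homo sapiens) for cytotoxicity, read by MTT assay, with a stated time of 48 h; a higher number here means that more compound is needed for the effect, a lower number that less compound is needed. Compound 1, `C=C(CC)C(=O)c1ccc(OCC(=O)NCC(=O)O)c(Cl)c1Cl`, gives only a limit of the assay, > 25000 nM, in this assay. Going by the values given here, compound 2, `C=C(CC)C(=O)c1ccc(OCC(=O)Nc2ccc(O)c(Cl)c2)c(Cl)c1Cl`, gives 5500 nM in this assay, the only definite number among the two. Among the compounds with values here, the single measured step, an at least 4.5-fold lower number from compound 1 to compound 2 (0.65 log units; beyond the scatter), ties the 3-chloro-4-hydroxyphenyl group on the amide-type nitrogen to the lower number, while the other value sits at the limit of > 25000 nM in this assay, at which 1 of the 2 values shown sits. Compound 3, `C=C(CC)C(=O)c1ccc(OCC(=O)NO)c(Cl)c1Cl`, is yet to be measured; it differs from compound 2 in hydroxy in place of 3-chloro-4-hydroxyphenyl on an amide-type nitrogen. Like the measured step run backwards, this trades the aromatic group for a small group on the amide-type nitrogen, so a rise toward the earlier limit is expected. Compound 3 is therefore estimated at 20000 nM, between 8000 nM and 60000 nM. The expected step of a 3.6-fold higher number from compound 2 to compound 3 (0.56 log units; beyond the scatter) would be a clear rise in this assay.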

Compound 3, half-maximal effective concentration: 4500 nM
The estimate for compound 3 lay 4.4-fold (0.65 log units) above the measured number, and the stated range ends above it.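

In this assay, the change from 3-chloro-4-hydroxyphenyl to hydroxy on the amide-type nitrogen removes an aromatic ring and most of the substituent's heavy atoms, yet the step stays within the scatter (a 1.2-fold lower number from compound 2 to compound 3 (0.09 log units; within the scatter)). A large aromatic group on this nitrogen is therefore not required for a number of this size, and small size alone does not account for the weak result of compound 1. Hydroxy in place of carboxymethyl gives a step beyond the scatter (an at least 5.5-fold lower number from compound 1 to compound 3 (0.74 log units; beyond the scatter)), but this step has only a lower bound: the limit of > 25000 nM in this assay, at which 1 of the 3 values shown sits.

The compounds shown leave open whether hydroxy itself matters on this nitrogen, as an unsubstituted amide or a methoxy group there would show. They also leave open whether carboxymethyl stands apart through its carboxylic acid, which the corresponding methyl ester would test.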